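The source may hold more compounds than are shown below. What is called first, only, known or untested is meant among the compounds shown, and "the series" means these compounds.

Measured so far:
compound 1 `COc1ccc(CCCN2CCC(COCc3ccccc3)CC2)cc1` gives 2100 nM
compound 2 `Clc1ccccc1CCCN1CCC(COC(c2ccccc2)c2ccccc2)CC1` gives 800 nM

In a functional assay on cells (T-cell line, Homo sapiens) for inhibition (on this read-out lower numbers stand for stronger inhibition and higher numbers for weaker inhibition), compound 1 gives 2100 nM and compound 2 gives 800 nM. Compound 2 has the lower of the two numbers, and the gap to compound 1 lies beyond the scatter, so compound 2 stands as the stronger inhibitor of the pair. Among the measured compounds shown here, the two compounds differ in more than one place, so no single structural step between measured compounds can be isolated.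

Compound 3 `COc1ccc(/C=C/CN2CCC(COC(c3ccccc3)c3ccccc3)CC2)cc1` keeps the core of compound 2 and changes the chain on the amine: 2-(4-methoxyphenyl)ethenyl in place of 2-(2-chlorophenyl)ethyl on a saturated chain carbon bound to an amine nitrogen in a ring. The entering group carries the methoxy-bearing aromatic ring also present in compound 1, here on a chain with a double bond, while the ether of compound 2 is retained.

For the measured compounds named here, with no single-point step available the direction is uncertain. Compound 1, the only other reference, gives the higher number 2100 nM, which argues for a modest loss rather than a gain. A step of a 1.9-fold higher number from compound 2 to compound 3 (0.27 log units; within the scatter) toward weaker inhibition is expected, near the edge of the scatter. Compound 3 is estimated at 1500 nM in this assay, within 500 nM to 5000 nM.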

Compound 3, half-maximal inhibitory concentration: 4300 nM
Beside the measured number, compound 3's estimate is 2.9-fold (0.46 log units) below it, and the stated range covers the measured number.
By their numbers in this assay, from the lowest: compound 2; then compound 1; then compound 3.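

In this assay, the exchange of 2-(2-chlorophenyl)ethyl for 2-(4-methoxyphenyl)ethenyl gives a 5.4-fold higher number from compound 2 to compound 3 (0.73 log units; beyond the scatter). Among the compounds shown here, with the ether and the rest of the shared core held constant, this is the first single-place comparison, and it shows that inhibition depends on the group at this place and that this exchange weakens it. The exchange is nevertheless composite, since the chlorine leaves while a methoxy group and a double bond outside the aromatic ring enter, and no measurement available here explains the weaker inhibition or assigns it to any one of these features.

The compounds shown leave open whether the loss follows the double bond or the change of substituent on the aromatic ring; 2-(4-methoxyphenyl)ethyl and 2-(2-chlorophenyl)ethenyl on the same core would separate the two. On these data alone, how a longer chain, or an amine or a carboxylic acid in the group at this place, would read out also remains open.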